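Exchanging the Aryl Group at a Saturated Ring Carbon

The source may report more compounds than this note shows. Statements on the series, on what has been measured and on what is new or still open speak of the compounds shown alone.

Measured compounds:
Compound 1, `CC1=C(C(=O)Nc2ccc(Cl)c(Cl)c2)C(c2cccc(Oc3ccccc3)c2)NC(=S)N1`: 9770 nM
Compound 2, `CC1=C(C(=O)Nc2ccc(Cl)c(Cl)c2)C(c2ccccc2Cl)NC(=S)N1`: 20000 nM

Of the compounds shown here, two have so far been measured in a functional assay on PC-3 cells (Homo sapiens) for cytotoxicity, read by sulforhodamine B assay, with a stated time of 48 h; on this read-out lower numbers stand for stronger inhibition of growth and higher numbers for weaker inhibition of growth. Compound 1 gives 9770 nM. Compound 2 gives 20000 nM, which is the highest of the two numbers; its nearest neighbour is compound 1, whose number is lower by a margin that lies beyond the scatter. Among the compounds with values here, no pair that differs in a single place has been measured, so no step between measured compounds can be stated.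

The next compound, compound 3 with structure `COc1cccc(C2NC(=S)NC(C)=C2C(=O)Nc2ccc(Cl)c(Cl)c2)c1`, is derived from compound 2 by one change: 3-methoxyphenyl in place of 2-chlorophenyl on a saturated ring carbon. Within the data shown here, no measured pair shows the effect of this change, so the expectation rests only on the two values above. Since compound 1 with 9770 nM carries a differently substituted aryl at the same place and shows the lower number, compound 3 is expected to move modestly in the same direction, with a step of a 1.7-fold lower number from compound 2 to compound 3 (0.22 log units; within the scatter) in this assay. The estimate for compound 3 in this assay is 12000 nM, within a range from 5000 nM to 30000 nM.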

Compound 3, concentration for 50% growth inhibition: 14500 nM
For compound 3 the middle estimate is 1.2-fold (0.08 log units) below the measured one; the range from low to high includes it.
By their numbers in this assay, from the lowest: compounds 1, 3 and 2 (each within the scatter of the next, the first and the last beyond it).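

In this assay, within the data shown here, the exchange of 2-chlorophenyl for 3-methoxyphenyl on a saturated ring carbon gives the first single change that can be read at this position, a 1.4-fold lower number from compound 2 to compound 3 (0.14 log units; within the scatter), so this exchange does not separate the two compounds on this read-out. Methyl in place of phenyl on an oxygen on an aromatic ring gives a 1.5-fold higher number from compound 1 to compound 3 (0.17 log units; within the scatter), which shows that shortening the group on that oxygen from phenyl to methyl also leaves the two compounds indistinguishable in this assay. Nothing available explains either step or gives any property of these groups as measured.

The compounds shown carry only aryl groups at this ring carbon, so it remains open whether a ring bearing an amine or a carboxylic acid, or a longer chain such as butyl on the oxygen, would give a step beyond the scatter. On these data alone, it also remains open whether an exchange at another place on the shared core, such as the methyl group or the amide, would do more than these exchanges on the aryl group.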